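The source may hold more compounds than are shown below. What is called first, only, known or untested is meant among the compounds shown, and "the series" means these compounds.

In a functional assay on CHO cells for antagonist activity at Orexin/Hypocretin receptor type 1 (Homo sapiens), read by FLIPR and calcium flux (a lower number here means a less potent compound, a higher number a more potent compound, by a factor of ten per unit of this negative logarithm), compound 1 `Cc1cc(C(F)(F)F)cc(NC[C@@H]2CC3(CC3)CN2C(=O)c2nc(C)sc2-c2ccccc2)n1` gives 7.8. In this assay compound 2 `Cc1cccc(NC[C@@H]2CC3(CC3)CN2C(=O)c2nc(C)sc2-c2ccccc2)n1` gives 7.3. In this assay compound 3 `O=C(c1nc(C(F)(F)F)ccc1-c1ncccn1)N1CC2(CC2)C[C@H]1CNc1ccc(C(F)(F)F)cn1` gives 6.7.

Compound 1 and compound 2 share one core and differ only in one spot: hydrogen in place of trifluoromethyl on an aromatic carbon. That change made a step of a number 0.50 log units lower from compound 1 to compound 2 (beyond the scatter), so the compound without the trifluoromethyl is the weaker of the two.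

Compound 3 sits on a different core; the difference between the two cores is not broken down here. Compound 4 `O=C(c1ncccc1-c1ncccn1)N1CC2(CC2)C[C@H]1CNc1ccc(C(F)(F)F)cn1` has not been measured yet. It differs from compound 3 by hydrogen in place of trifluoromethyl on an aromatic carbon. Going by the values given here, this is the same kind of change as the one from compound 1 to compound 2, but the surroundings differ: in compound 1 the trifluoromethyl is "meta to a methyl group" and "opposite the ring nitrogen", while in compound 3 it is "next to the ring nitrogen" and "para to a pyrimidin-2-yl group".

Among the compounds with values here, for compound 4 a step of about a number 0.50 log units lower from compound 3 to compound 4 (beyond the scatter) is expected in this assay, resting on the single earlier step of a number 0.50 log units lower from compound 1 to compound 2 (beyond the scatter). Since that step rests on one pair on another core, the uncertainty is wide. Compound 4 is estimated at 6.2, between 5.5 and 6.9.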

Compound 4, negative logarithm of the antagonist equilibrium constant: 7.7
Compound 4: the middle estimate sits 1.50 log units below what was measured, outside the stated range (above it).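

Replacing the trifluoromethyl with hydrogen gave a number 1.00 log units higher from compound 3 to compound 4 (beyond the scatter) in this assay, so on this core the compound without the group is the stronger of the two. The same swap therefore did not carry over from one core to the other, not even in its direction: the same change on two cores in this assay, a number 0.50 log units lower (beyond the scatter) from compound 1 to compound 2 and a number 1.00 log units higher (beyond the scatter) from compound 3 to compound 4, 1.50 log units apart, beyond the scatter of two such steps

Going by these compounds alone, what this does not show is the reason for the split: the trifluoromethyl stands in different surroundings on the two cores, the cores differ elsewhere as well, and each core offers only one pair, so no general rule follows for either core.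

The compounds shown leave open how a chlorine atom, a methoxy group or a nitrile would read at the aromatic carbon that carries only hydrogen in compound 4. They also leave open whether the swap would keep its direction on the core of compound 3 if a phenyl group took the place of the pyrimidin-2-yl group.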